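A few compounds are considered here, and "the series" means these few. Any claim that something is new, unique, unknown or untested is made for them only; others in the source may bear on it.

Measured so far:
compound 1 `Nc1cc(C(F)(F)F)cc2c(=O)cc(N3CCN(CC4CCCCC4)CC3)sc12` — 69.4%
compound 2 `O=C(OC1CCC(CN2CCN(c3cc(=O)c4cc(C(F)(F)F)cc([N+](=O)[O-])c4s3)CC2)CC1)c1ccco1` — 0.6%
compound 3 `CS(=O)(=O)NC1CCC(CN2CCN(c3cc(=O)c4cc(C(F)(F)F)cc([N+](=O)[O-])c4s3)CC2)CC1` — 111%

In an ADME assay on cells (Hepatocyte, Mus musculus) for metabolic stability, with a stated time of 30 min (a higher number here means that more of the compound is left, a lower number that less of the compound is left), compound 3 gives 111%, the highest of the three numbers; compound 1 sits lower beyond the scatter, compound 2 far lower still. Compound 4 `CC(=O)NC1CCC(CN2CCN(c3cc(=O)c4cc(C(F)(F)F)cc([N+](=O)[O-])c4s3)CC2)CC1` differs from compound 3 by acetyl in place of methylsulfonyl on an amine nitrogen. Among the compounds with values here, only one measured step touches this part of the molecule: a number 110.4 percentage points higher from compound 2 to compound 3 (beyond the scatter), a large gain, but it exchanged the whole group on the saturated ring carbon. Within the data shown here, no measured step swaps one group for another on the amine nitrogen, so the expectation rests on analogy alone: acetamido keeps a nitrogen bearing a hydrogen-bond acceptor, so a small downward step or none beyond the scatter is expected, a number 23 percentage points lower from compound 3 to compound 4 (beyond the scatter). For compound 4 the estimate is 88%, ranging from 50% to 115%.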

Compound 4, percent of the compound remaining: 94.9%
The estimate for compound 4 lay 6.9 percentage points below the measured number; the measured number falls inside the stated range.
By their numbers in this assay, from the lowest: compound 2; then compound 1; then compound 4; then compound 3.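

In this assay, the group on the amine nitrogen has a measurable effect: a number 16.1 percentage points lower from compound 3 to compound 4 (beyond the scatter), a modest step with acetyl in place of methylsulfonyl. The large gain over the furan ester is not confined to methanesulfonamido, as acetamido on the saturated ring carbon also shows a number 94.3 percentage points higher from compound 2 to compound 4 (beyond the scatter). Nothing available bears on the cause of either step.

On these data alone, how a free amine or a urea at that nitrogen would read remains open. As far as these compounds go, it is also open whether the low ester number belongs to the ester linkage or to the furan ring, a question that a furan-2-carboxamide would address.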